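A few compounds are considered here, and "the series" means these few. Any claim that something is new, unique, unknown or untested is made for them only; others in the source may bear on it.

Measured in a functional assay on HCT-116 cells (Homo sapiens) for inhibition; a lower number here means a stronger inhibitor, a higher number a weaker inhibitor:
- compound 1 `CCNC(=O)c1noc(-c2cc(C(C)C)c(O)cc2O)c1-c1cc(CO)no1`: 13 nM
- compound 2 `CCNC(=O)c1noc(-c2cc(C(C)C)c(O)cc2O)c1-c1cc(CN)no1`: 84 nM
- compound 3 `CCCNCc1cc(-c2c(C(=O)NCC)noc2-c2cc(C(C)C)c(O)cc2O)on1`: 117 nM

Compound 3 sits level with compound 2 and clearly above compound 1. Amino in place of hydroxy gave a 6.5-fold higher number from compound 1 to compound 2 (0.81 log units; beyond the scatter), and propylamino in place of hydroxy gave a 9.0-fold higher number from compound 1 to compound 3 (0.95 log units; beyond the scatter). Propyl in place of hydrogen on the amine nitrogen gave a 1.4-fold higher number from compound 2 to compound 3 (0.14 log units; within the scatter).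

Compound 4 `CCNC(=O)c1noc(-c2cc(C(C)C)c(O)cc2O)c1-c1cc(CNC(C)=O)no1` differs from compound 3 by acetyl in place of propyl on an amine nitrogen. Going by the values given here, no measured compound carries acetyl there, so only the span of these steps guides the expectation. A modest fall in this assay is expected, landing inside that span. The expected step is a 2.3-fold lower number from compound 3 to compound 4 (0.37 log units; beyond the scatter). For compound 4 the estimated value is 50 nM, with an expected range of 15 nM to 160 nM.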

Compound 4, half-maximal inhibitory concentration: 167 nM
Compound 4: middle estimate off by 3.3-fold (0.52 log units), on the low side, outside the stated range (above it).
By their numbers in this assay, from the lowest: compound 1; then compounds 2, 3 and 4 (each within the scatter of the next).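

In this assay, acetyl in place of propyl on the amine nitrogen (a 1.4-fold higher number from compound 3 to compound 4 (0.15 log units; within the scatter)) and acetyl in place of hydrogen (a 2.0-fold higher number from compound 2 to compound 4 (0.30 log units; within the scatter)) both stay within the scatter, so the acetamido compound sits level with the two amines. Acetamido in place of hydroxy (a 13-fold higher number from compound 1 to compound 4 (1.11 log units; beyond the scatter)) leaves it clearly apart, so among the groups shown at this carbon, only hydroxy stands out from the rest. Nothing at hand explains this result. Open, on these data alone, is whether a methoxy group or a carboxylic acid here would match compound 1.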